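The compounds below may be only part of what the source reports. "The series", "measured", "known", "first", "only" and "open" are said of these compounds alone.

Series notes. The three measured analogues share one core and differ only in the group on the saturated chain carbon bound to the sulfur. Compound 1 `Cc1cc(N2CC[C@@H](C)[C@@H](N(C)c3ncnc4[nH]ccc34)C2)n2nc(SCc3ccccc3)nc2n1` carries phenyl there; in a toxicity assay on GES1 cells (Homo sapiens) for inhibition, read by MTT assay, with a stated time of 72 h (on this read-out lower numbers stand for stronger inhibition and higher numbers for weaker inhibition), compound 1 gives 67200 nM. Compound 2 `Cc1cc(N2CC[C@@H](C)[C@@H](N(C)c3ncnc4[nH]ccc34)C2)n2nc(SCc3csc4ccc(Cl)cc34)nc2n1` carries 5-chloro-1-benzothiophen-3-yl at that carbon, and in this assay compound 2 reaches only the assay limit, > 100000 nM. Compound 3 `C=CCSc1nc2nc(C)cc(N3CC[C@@H](C)[C@@H](N(C)c4ncnc5[nH]ccc45)C3)n2n1` carries vinyl there, and in this assay compound 3 likewise stops at the assay limit, > 100000 nM. The step of an at least 1.4-fold higher number from compound 1 to compound 2 (0.17 log units; that floor lies within the scatter) and the step of an at least 1.4-fold higher number from compound 1 to compound 3 (0.17 log units; that floor lies within the scatter) both end in a limit, and a step that the two limits leave unreadable from compound 2 to compound 3 cannot be sized since both ends sit at the limit of > 100000 nM in this assay, at which 2 of the 3 values shown sit. Compound 2 therefore stands on the numbers shown with only a limit and no number of its own.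

Among the compounds with values here, compound 4 `Cc1cc(N2CC[C@@H](C)[C@@H](N(C)c3ncnc4[nH]ccc34)C2)n2nc(SCCCc3ccccc3)nc2n1` is not yet measured. phenethyl in place of 5-chloro-1-benzothiophen-3-yl on a saturated chain carbon bound to a sulfur The measured steps at this position all ran from the one real number of compound 1 toward a limit, and the step leaving compound 2 gives no readable size. No shift beyond the scatter is expected in this assay for compound 4, and the step of an at least 1.1-fold lower number from compound 2 to compound 4 (0.04 log units; that floor lies within the scatter) is expected to be small. Compound 4 is expected to give about 90000 nM, within 40000 nM to 200000 nM, with a fair chance that only a limit is again reported.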

Compound 4, half-maximal inhibitory concentration: > 100000 nM
Compound 4 was reported as a limit; the forecaster's own chance of this, stated with the estimate: 50%; at least 1.1-fold (0.04 log units) between middle value and limit.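

In this assay compound 4 also ends at a limit, > 100000 nM, and this is a limit and not a number. The position now holds a third group that stops at the limit: phenethyl, a carbon-only group with one six-membered aromatic ring, joins 5-chloro-1-benzothiophen-3-yl and vinyl, so reaching the limit does not depend on the ring sulfur or chlorine of compound 2, and compound 1 with phenyl remains the one exception: the limit of > 100000 nM in this assay, at which 3 of the 4 values shown sit.

Within the data shown here, the single readable new step is an at least 1.4-fold higher number from compound 1 to compound 4 (0.17 log units; that floor lies within the scatter), so lengthening the chain from the phenyl of compound 1 to the phenethyl of compound 4 shows no shift beyond the scatter, while the steps reaching compound 4 from compound 2 and from compound 3 cannot be read.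

From the compounds shown here alone, how the three groups at the limit order among themselves stays open, as none of them has a number of its own. Also open, going by these compounds, is whether an amine or a carboxylic acid on the chain at this position would give a readable value clearly lower than that of compound 1.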